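Swapping a furan for a thiophene on a biaryl core

The source may hold more compounds than are shown below. What is called first, only, known or untested is meant among the compounds shown, and "the series" means these compounds.

Among the measured compounds shown here, compound 2 `c1ccc(-c2ccoc2)c(OCC2=NCCN2)c1` gives 5.01 nM in a functional assay for activation of Alpha-1D adrenergic receptor (Homo sapiens), read by calcium flux; a lower number here means that less compound is needed, a higher number that more compound is needed for the effect; the only other number so far, compound 1 `c1c[nH]c(-c2ccccc2OCC2=NCCN2)c1` with 6.31 nM, lies within the scatter of it. For the measured compounds named here, the one measured step, a 1.3-fold lower number from compound 1 to compound 2 (0.10 log units; within the scatter), exchanged one five-membered ring for another and left the number essentially unchanged. Compound 3 `c1ccc(-c2ccsc2)c(OCC2=NCCN2)c1` carries a change of the same kind: thiophen-3-yl in place of furan-3-yl on an aromatic carbon. That single step bears on it only loosely, yet it points to no movement beyond the scatter. The expected step is a 1.0-fold lower number from compound 2 to compound 3 (0.00 log units; within the scatter). Compound 3 is therefore estimated at 5 nM, with a range from 1.6 nM to 16 nM.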

Compound 3, half-maximal effective concentration: 12.6 nM
Compound 3: the middle estimate sits 2.5-fold (0.40 log units) below what was measured; low and high end bracket the measured number.
By their numbers in this assay, from the lowest: compounds 2, 1 and 3 (each within the scatter of the next, the first and the last beyond it).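

Thiophen-3-yl and furan-3-yl match in every count given for them and differ only in sulfur for oxygen, yet this exchange gives a 2.5-fold higher number from compound 2 to compound 3 (0.40 log units; beyond the scatter) in this assay and so a step beyond the scatter. The other new step is a 2.0-fold higher number from compound 1 to compound 3 (0.30 log units; within the scatter) and stays within the scatter, so among these three compounds only compound 2 and compound 3 stand clearly apart. No measurement at hand explains that gap.

Still open, going by these compounds, is how an amine or a carboxylic acid would fare on this aromatic carbon in place of a five-membered ring. Also open, on these data alone, is whether the change from furan-3-yl to thiophen-3-yl has the same size on another core.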